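The source may report more compounds than this note shows. Statements on the series, on what has been measured and on what is new or still open speak of the compounds shown alone.

In an assay on MDA-MB-231 cells for binding affinity to C-X-C chemokine receptor type 4 (Homo sapiens), read by fluorescence and microscopy, with stated times of 10 min and 30 min (on this read-out lower numbers stand for an effect already at smaller amounts and higher numbers for an effect only at larger amounts of compound), compound 1 `CCN(CC)Cc1ccc(S(=O)(=O)NCc2ccc(CNC(=O)c3ccc(F)cc3)cc2)cc1` gives 1 nM, while compound 2 `O=C(NCc1ccc(CNS(=O)(=O)c2ccc3c(c2)CCO3)cc1)c1ccc(F)cc1` gives 10 nM. Compound 2 therefore stands at the higher of the two numbers obtained, and its nearest neighbour is compound 1, separated from it by a gap that lies beyond the usual scatter. Compound 3 `Cc1ccc(S(=O)(=O)NCc2ccc(CNC(=O)c3ccc(F)nc3)cc2)cc1` reaches only a limit of this assay, > 1000 nM, which is the limit of > 1000 nM in this assay, at which 1 of the 3 values shown sits.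

Compound 4 `O=C(NCc1ccc(CNS(=O)(=O)c2ccccc2Cl)cc1)c1ccc(F)cc1` differs from compound 2 in a single place: a group of 7 heavy atoms (6 carbon, 1 chlorine; one six-membered aromatic ring of carbon only) in place of a group of 9 heavy atoms (8 carbon, 1 oxygen; one five-membered non-aromatic ring with 1 hetero atom, one six-membered aromatic ring of carbon only), on a sulfonyl sulfur. Among the measured compounds shown here, no measured pair shows what such an exchange does, so the expectation rests on compound 2 alone, with a small upward step, if any, anticipated. In this assay compound 4 is estimated at 20 nM, with a range from 4 nM to 100 nM. The expected step of a 2.0-fold higher number from compound 2 to compound 4 (0.30 log units; within the scatter) is estimated to sit within the scatter.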

Compound 4, effective concentration (reported as EC, without a stated level of effect): 1000 nM
Estimate against measurement, compound 4: 50-fold (1.70 log units) below, and the stated range ends below it.
By their numbers in this assay, from the lowest: compound 1; then compound 2; then compound 4.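

Putting 2-chlorophenyl on the sulfonyl sulfur in place of the group with the five-membered non-aromatic ring gives, in this assay, a 100-fold higher number from compound 2 to compound 4 (2.00 log units; beyond the scatter). Among the compounds shown here, this is the first step read at this position, and it shows that the number there depends strongly on the group carried. The higher end of this step reaches the figure of the limit: the limit of > 1000 nM in this assay, at which 1 of the 4 values shown sits.

As far as these compounds go, it remains open whether the chlorine, the departure of the five-membered ring, or both account for the step. A plain phenyl, or a methoxy group or an amine in place of the chlorine, would bear on that question.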